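From Methyl to Ethyl on the Thioether Phenyl

The compounds below may be only part of what the source reports. "The series", "measured", "known", "first", "only" and "open" are said of these compounds alone.

Measured compounds:
Compound 1, `Cc1ccc(SCc2ccc(C(=O)Nc3ccccc3N)cc2)cc1`: 3270 nM
Compound 2, `CC(C)(C)c1ccc(SCc2ccc(/C=C/C(=O)Nc3ccccc3N)cc2)cc1`: 640 nM

In a functional assay on A549 cells (Homo sapiens) for antiproliferative activity, read by CCK-8 assay, with a stated time of 72 h (a higher number here means a weaker inhibitor, a lower number a stronger inhibitor), compound 1 gives 3270 nM, the highest of the two numbers shown. Among the compounds with values here, compound 2 differs from compound 1 in more than one place, so no single step connects them; the two values show only that compound 2 gives 640 nM, a lower number that lies beyond the scatter.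

The unmeasured compound 3, `CCc1ccc(SCc2ccc(C(=O)Nc3ccccc3N)cc2)cc1`, differs from compound 1 by methyl in place of hydrogen on a saturated chain carbon bound to an aromatic carbon. This is a single added carbon on a group far from the amide part shared by both compounds. Within the data shown here, no measured pair shows the effect of such a change here, so the expectation rests on its small size alone.

For compound 3 the step of a 1.3-fold lower number from compound 1 to compound 3 (0.10 log units; within the scatter) is expected to stay within the scatter, with no clear direction. The estimate for compound 3 in this assay is 2600 nM, ranging from 1100 nM to 6000 nM.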

Compound 3, half-maximal inhibitory concentration: 3040 nM
Estimate against measurement, compound 3: 1.2-fold (0.07 log units) below, and the stated range covers the measured number.
By their numbers in this assay, from the lowest: compound 2; then compounds 3 and 1 (each within the scatter of the next).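

In this assay, within the data shown here, the change from 4-methylphenyl to 4-ethylphenyl gives a 1.1-fold lower number from compound 1 to compound 3 (0.03 log units; within the scatter) and is the first step here that alters only one place. At this position, on a saturated chain carbon bound to an aromatic carbon, adding one methyl therefore gives two numbers that cannot be told apart, something the earlier pair, which differs in more than one place, could not show. Nothing measured here bears on why this is so.

Going by these compounds, it remains open whether a longer chain such as propyl, or an amine or a carboxylic acid at this place, would move the number beyond the scatter. Compound 2 differs from compound 1 in more than one place and gives no separate reading of the group on this phenyl.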